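Swapping the fluorine on the benzyl group for methyl

The compounds below may be only part of what the source reports. "The series", "measured", "known", "first", "only" and "open" are said of these compounds alone.

Three related inhibitors share one core and differ only in the aryl group that sits on a saturated chain carbon bound to an amide-type nitrogen. In an assay on microsomes from liver for inhibition of 3-hydroxy-3-methylglutaryl-coenzyme A reductase (Rattus norvegicus), read by scintillation counting, with stated times of 0.5 h and 0.75 h (a lower number here means a stronger inhibitor, a higher number a weaker inhibitor), compound 1 `O=C(O)C[C@H](O)C[C@H](O)CCn1c(-c2ccc(F)cc2)nc(C(=O)NCc2ccccc2F)c1C1CC1` gives 1.5 nM. Compound 2 `COc1ccc(CNC(=O)c2nc(-c3ccc(F)cc3)n(CC[C@@H](O)C[C@@H](O)CC(=O)O)c2C2CC2)cc1F` gives 3.7 nM in this assay, and compound 3 `O=C(O)C[C@H](O)C[C@H](O)CCn1c(-c2ccc(F)cc2)nc(C(=O)NCc2ccc(F)cc2)c1C1CC1` gives 3.4 nM in this assay. Compound 3 therefore stands second highest of the three numbers, within the scatter of compound 2 and clearly weaker than compound 1, as the step of a 2.3-fold higher number from compound 1 to compound 3 (0.36 log units; beyond the scatter) shows.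

Compound 4 `Cc1cccc(CNC(=O)c2nc(-c3ccc(F)cc3)n(CC[C@@H](O)C[C@@H](O)CC(=O)O)c2C2CC2)c1` carries the change (3-methylphenyl in place of 4-fluorophenyl on a saturated chain carbon bound to an amide-type nitrogen). Among the measured compounds shown here, no measured pair tests a methyl group at this position, so the nearest guides are the three aryl swaps already seen: a 2.5-fold higher number from compound 1 to compound 2 (0.39 log units; beyond the scatter), a 2.3-fold higher number from compound 1 to compound 3 (0.36 log units; beyond the scatter) and a 1.1-fold lower number from compound 2 to compound 3 (0.04 log units; within the scatter). Moving a substituent around this ring moved the number only modestly, and two of the three variants sit within the scatter of each other. The expectation is therefore a step no larger than modest in this assay, with no clear direction, so that a 1.0-fold higher number from compound 3 to compound 4 (0.01 log units; within the scatter) is estimated to stay close to the scatter. Compound 4 is expected to give about 3.5 nM, with a likely range from 1.5 nM to 9 nM.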

Compound 4, half-maximal inhibitory concentration: 7.2 nM
Estimate against measurement, compound 4: 2.1-fold (0.31 log units) below; the measured number falls inside the stated range.
By their numbers in this assay, from the lowest: compound 1; then compounds 3, 2 and 4 (each within the scatter of the next, the first and the last beyond it).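

Compound 4 is the only one of the four whose aryl group carries no fluorine, and in this assay replacing 4-fluorophenyl with 3-methylphenyl gives a step beyond the scatter (a 2.1-fold higher number from compound 3 to compound 4 (0.33 log units; beyond the scatter)). Against the other two compounds the picture differs: the step to compound 4 from the methoxy-bearing compound stays within the scatter (a 1.9-fold higher number from compound 2 to compound 4 (0.29 log units; within the scatter)), while the step from the 2-fluorophenyl compound is the largest in the set, though still modest (a 4.8-fold higher number from compound 1 to compound 4 (0.68 log units; beyond the scatter)). This place on the chain therefore accepts all four aryl groups with only modest steps, yet the choice of group still shifts the number measurably, and no measurement shown offers a reason for these steps.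

The change from compound 3 to compound 4 alters both the substituent and its place on the ring, so the effect of swapping fluorine for methyl cannot be separated from the effect of moving it. A 4-methylphenyl or 3-fluorophenyl group would separate the two, while a phenyl group without a substituent, or a ring bearing an amine or a carboxylic acid, would show how far this place tolerates other groups.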